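This account rests on a few compounds, and the source may have more. Where it says the series, first, only, none or still open, it means among the compounds named here.

Measured so far:
compound 1, `Cc1nc(-c2ccc(C(F)(F)F)cc2)sc1CNc1ccc(CC(=O)O)cc1`, 18%
compound 2, `Cc1nc(-c2ccc(C(F)(F)F)cc2)sc1CNc1ccc(CCCC(=O)O)cc1`, 44%

In a functional assay on CHO cells for agonist activity at Free fatty acid receptor 1 (Homo sapiens), read by a luciferase reporter (a lower number here means a smaller maximal response, a higher number a larger maximal response), compound 2 stands highest of the two numbers; its nearest neighbour is compound 1, and the step of a number 26 percentage points higher from compound 1 to compound 2 (beyond the scatter) lies beyond the scatter. Compound 3, `Cc1nc(-c2ccc(C(F)(F)F)cc2)sc1CNc1ccc(/C=C/C(=O)O)cc1`, has not yet been measured in this assay. It differs from compound 2 in one place: 2-carboxyethenyl in place of 3-carboxypropyl on an aromatic carbon. Among the compounds with values here, only one measured step bears on this change, a number 26 percentage points higher from compound 1 to compound 2 (beyond the scatter), which shows that a longer carboxy-bearing chain gave a larger maximal response than the shortest one. Within the data shown here, the entering group of compound 3 is shorter than the group it replaces but longer than that of compound 1, and it carries a double bond that neither measured compound has, so no measured pair settles the direction. Compound 3 is therefore estimated to fall between the two measured values, with an expected step of a number 9 percentage points lower from compound 2 to compound 3 (within the scatter) in this assay. The estimate for compound 3 is 35%, with a range from 15% to 60%.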

Compound 3, largest response reached (reported as percent of maximum), in percent of the reference or control that the assay uses: 95%
For compound 3 the middle estimate is 60 percentage points below the measured one, and the stated range ends below it.
By their numbers in this assay, from the lowest: compound 1; then compound 2; then compound 3.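

In this assay, the substituent on the aromatic carbon para to a large group does not act through chain length alone: 2-carboxyethenyl in place of 3-carboxypropyl gives a number 51 percentage points higher from compound 2 to compound 3 (beyond the scatter), although it has the fewer heavy atoms. In place of carboxymethyl, the same group gives a number 77 percentage points higher from compound 1 to compound 3 (beyond the scatter), so compound 3 goes against the rise with chain length that the first pair suggested. No measurement shown accounts for these large steps.

The compounds shown leave open how much of the gain belongs to the double bond and how much to chain length, a question that a saturated 2-carboxyethyl chain would bear on. They also leave open whether a tetrazole could stand in for the carboxylic acid on the two-carbon unsaturated chain.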